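The source may hold more compounds than are shown below. What is called first, only, known or untested is meant among the compounds shown, and "the series" means these compounds.

Working notes on the series. Compound 3 `CCCOC(=O)C1=C(C)NC(C)=C(C(=O)OCC)C1c1[nH]cnc1Cl` gives 407 nM in an assay on isolated protein for inhibition of Voltage-dependent L-type calcium channel subunit alpha-1C (Cavia porcellus); a higher number here means a weaker inhibitor, a lower number a stronger inhibitor. Compound 1 `CCOC(=O)C1=C(C)NC(C)=C(C(=O)OCC)C1c1[nH]cnc1Cl` gives 437 nM, and compound 2 `CCOC(=O)C1=C(C)NC(C)=C(C(=O)OC)C1c1[nH]cnc1Cl` gives 661 nM; the steps of a 1.1-fold lower number from compound 1 to compound 3 (0.03 log units; within the scatter) and a 1.6-fold lower number from compound 2 to compound 3 (0.21 log units; within the scatter) both stay within the scatter, so compound 3 stands among the other two rather than apart from them. Compound 4 `CCOC(=O)C1=C(C)NC(C)=C(C(=O)OC(C)(C)C)C1c1[nH]cnc1Cl` differs from compound 3 by tert-butyl in place of propyl on an oxygen next to a carbonyl group. The ester changes measured so far, a 1.5-fold higher number from compound 1 to compound 2 (0.18 log units; within the scatter), a 1.1-fold lower number from compound 1 to compound 3 (0.03 log units; within the scatter) and a 1.6-fold lower number from compound 2 to compound 3 (0.21 log units; within the scatter), all lie within the scatter, and none of them covers a branched group; the data give no basis for a larger move. A step of a 1.2-fold higher number from compound 3 to compound 4 (0.09 log units; within the scatter) is therefore expected, with no change beyond the scatter in this assay. Compound 4 is estimated at 500 nM, within a range from 200 nM to 1300 nM.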

Compound 4, half-maximal inhibitory concentration: 1660 nM
Compound 4: the middle estimate sits 3.3-fold (0.52 log units) below what was measured; measured number outside the range, above it.
By their numbers in this assay, from the lowest: compounds 3, 1 and 2 (each within the scatter of the next); then compound 4.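

Among these compounds, on an oxygen next to a carbonyl group, tert-butyl is the first change to move the number in this assay beyond the scatter, against propyl (a 4.1-fold higher number from compound 3 to compound 4 (0.61 log units; beyond the scatter)), ethyl (a 3.8-fold higher number from compound 1 to compound 4 (0.58 log units; beyond the scatter)) and methyl (a 2.5-fold higher number from compound 2 to compound 4 (0.40 log units; beyond the scatter)). Methyl, ethyl and propyl at this position remain within the scatter of one another, so the rise in the number appears only with tert-butyl among the four groups. Nothing available bears on the reason for this step. Still open, on these data alone, is how isopropyl or a longer chain such as butyl would read here, and so whether branching or chain size tracks with the higher number.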